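Cyclohexyl to methyl on the amide of compound 1

The source may report more compounds than this note shows. Statements on the series, on what has been measured and on what is new or still open speak of the compounds shown alone.

Compound 1 `O=C(Nc1nnc(-c2cccc(O)c2O)s1)C1CCCCC1` is one of three compounds that share a core and differ in the group on the carbonyl carbon of the amide. In a functional assay, with a stated time of 30 min, in the absence of a further agent (on this read-out higher numbers stand for weaker inhibition and lower numbers for stronger inhibition), compound 1 gives 19900 nM, the lowest of the three numbers. The nearest is compound 3 `O=C(Nc1nnc(-c2ccc(O)c(O)c2)s1)C1CCCCC1`, which gives 37300 nM in this assay, a gap within the scatter, so no order between compound 1 and compound 3 can be read from these two values. Compound 2 `O=C(Nc1nnc(-c2ccc(O)c(O)c2)s1)c1ccc(Cl)cc1` gives 53000 nM in this assay, a gap from compound 1 that lies beyond the scatter.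

Compound 4 `CC(=O)Nc1nnc(-c2cccc(O)c2O)s1` is not yet measured. It differs from compound 1 in one place: methyl in place of cyclohexyl on a carbonyl carbon. Among the compounds with values here, the only measured step between single-point neighbours, a 1.4-fold lower number from compound 2 to compound 3 (0.15 log units; within the scatter), exchanges one group on the carbonyl carbon for another and falls within the scatter, but it sits on a different core and does not involve methyl, so it bears on the present change only loosely. Within the data shown here, no measured step shows what removing the six-membered ring for a one-carbon group does in this assay.

Compound 4 is therefore expected to stay close to compound 1, with a 2.0-fold higher number from compound 1 to compound 4 (0.30 log units; within the scatter) as the estimated step, and the estimate for compound 4 in this assay is 40000 nM with a range from 12000 nM to 150000 nM.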

Compound 4, half-maximal inhibitory concentration: 111000 nM
Compound 4: the middle estimate sits 2.8-fold (0.44 log units) below what was measured; low and high end bracket the measured number.
By their numbers in this assay, from the lowest: compounds 1, 3 and 2 (each within the scatter of the next, the first and the last beyond it); then compound 4.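

In this assay the group on the carbonyl carbon of the amide now gives a step beyond the scatter, with a 5.6-fold higher number from compound 1 to compound 4 (0.75 log units; beyond the scatter) for methyl in place of cyclohexyl. Within the data shown here, the only earlier step at this place, a 1.4-fold lower number from compound 2 to compound 3 (0.15 log units; within the scatter) on a different core, stayed within the scatter and could not show that this place responds to the group it carries. On the core of compound 1 the number does respond, but this single pair cannot separate the loss of the six-membered non-aromatic ring from the drop from 6 heavy atoms to 1, and no measurement at hand bears on the reason for the step.

Still open, from the compounds shown here alone, is where ethyl, isopropyl or cyclopropyl on the carbonyl carbon would fall relative to compound 1 and compound 4, and what a longer chain ending in an amine or a carboxylic acid would do at this place. Also open, going by these compounds, is whether methyl in place of cyclohexyl gives a step of similar size on the core of compound 3, and where 4-chlorophenyl falls on the core of compound 1.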